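Trimming the Amide Aryl Group: What Compound 4 Might Give

The source may report more compounds than this note shows. Statements on the series, on what has been measured and on what is new or still open speak of the compounds shown alone.

Compound 1, `COc1cc(-c2nn(-c3cccc(NC(=O)c4cccc(C(F)(F)F)c4)c3)cc2-c2ccncc2)ccc1Cl`, gives > 50000 nM in a functional assay on NCI-H322M cells (Homo sapiens) for inhibition, read by sulforhodamine B assay, with a stated time of 48 h (a lower number here means a stronger inhibitor of growth, a higher number a weaker inhibitor of growth), which is a limit of this assay.
Compound 2, `COc1cc(-c2nn(-c3cccc(NC(=O)c4ccc(Cl)c(C(F)(F)F)c4)c3)cc2-c2ccncc2)ccc1Cl`, gives > 32500 nM in this assay, again a limit.
Compound 3, `O=C(Nc1cccc(-n2cc(-c3ccncc3)c(-c3ccc(Cl)c(O)c3)n2)c1)Nc1cc(C(F)(F)F)cc(C(F)(F)F)c1`, gives 5390 nM in this assay.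

Compound 2 stands at a limit of this assay and not at a measured number; its value sits at the limit of > 32500 nM in this assay, at which 1 of the 3 values shown sits. Compound 1 likewise sits at a limit, (the limit of > 50000 nM in this assay, at which 1 of the 3 values shown sits). Among the measured compounds shown here, the one step between measured compounds that differ in a single place, a step that the two limits leave unreadable from compound 1 to compound 2, is therefore unreadable. For the measured compounds named here, compound 3, which differs from compound 2 in more than one place, is the only compound here with a number.

Compound 4, `COc1cc(-c2nn(-c3cccc(NC(=O)c4ccccc4)c3)cc2-c2ccncc2)ccc1Cl`, differs from compound 2 in one place: phenyl in place of 4-chloro-3-(trifluoromethyl)phenyl on a carbonyl carbon. Going by the values given here, no measured step bears on this change, so no direction can be read from the data; what is known is only that compound 2 sits at a limit. Compound 4 is therefore expected to remain weak, most probably again at a limit, with an estimated step that the limit leaves unreadable from compound 2 to compound 4. The estimate for compound 4 is 45000 nM, with a range from 10000 nM to 120000 nM.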

Compound 4, concentration for total growth inhibition: > 100000 nM
Compound 4: a limit, no number (the forecaster's own chance of this, stated with the estimate: 70%); middle value at least 2.2-fold (0.34 log units) away from the limit.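

Among the compounds shown here, compound 4 gives > 100000 nM in this assay, which is a limit, and compound 1 and compound 2 also stand at limits, so no step to compound 4 can be read. The compounds shown leave open whether phenyl or 4-chloro-3-(trifluoromethyl)phenyl on the carbonyl carbon gives the stronger inhibitor of growth.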